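The source may report more compounds than this note shows. Statements on the series, on what has been measured and on what is new or still open speak of the compounds shown alone.

Compound 1 `N#Cc1ccc(NC(=O)c2cccc(Br)c2O)cc1`: 3260 nM
Compound 2 `Cc1cc(C#N)ccc1NC(=O)c1ccc2cccnc2c1O`: 3240 nM

In a functional assay on KG-1 cells (Homo sapiens) for cytotoxicity, read by luminescence and CellTiter-Glo, with a stated time of 3 days (on this read-out higher numbers stand for weaker inhibition and lower numbers for stronger inhibition), compound 1 gives 3260 nM and compound 2 gives 3240 nM, so the two stand level within the scatter. Compound 3 `Cc1cccc(C(=O)Nc2ccc(C#N)cc2)c1O` keeps the core of compound 1 and changes in one place: methyl in place of bromo on an aromatic carbon, with methyl in place of bromo on an aromatic carbon. Among the compounds with values here, no measured pair shows this change, so the expectation is only a small move toward a higher number, possibly none beyond the scatter. The expected step is a 1.2-fold higher number from compound 1 to compound 3 (0.09 log units; within the scatter). For compound 3 the estimate is 4000 nM, with an expected range of 1500 nM to 10000 nM.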

Compound 3, half-maximal inhibitory concentration: 8980 nM
Compound 3: middle estimate off by 2.2-fold (0.35 log units), on the low side; low and high end bracket the measured number.
By their numbers in this assay, from the lowest: compounds 2 and 1 (each within the scatter of the next); then compound 3.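

In this assay, methyl in place of bromo on an aromatic carbon, ortho to a hydroxy group, gives a 2.8-fold higher number from compound 1 to compound 3 (0.44 log units; beyond the scatter) and so a modest loss of inhibition. This position is therefore not indifferent to the group it carries, and of these two groups bromo gives the stronger inhibition. Nothing available explains this difference between two groups of one heavy atom each. As far as these compounds go, how chloro, methoxy or an amine on the same carbon would compare remains open, as does whether this step holds on another core.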